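A few compounds are considered here, and "the series" means these few. Any claim that something is new, unique, unknown or untested is made for them only; others in the source may bear on it.

Working notes on the series. In a functional assay on the whole organism (arterial blood) with Rattus norvegicus as the target (on this read-out lower numbers stand for an effect already at smaller amounts and higher numbers for an effect only at larger amounts of compound), compound 1 (`Cc1nc2cnccc2n1CC1CCN(C(=O)CC(C)c2ccccc2)CC1`) gives 0.033 mg/kg, the middle position among the three measured compounds. Compound 2 (`Cc1nc2cnccc2n1CC1CCN(S(=O)(=O)CC(C)(C)c2ccccc2)CC1`) gives a higher number, 0.087 mg/kg. Compound 3 (`Cc1nc2cnccc2n1CC1CCN(C(=O)C=C(c2ccccc2)c2ccccc2)CC1`) gives a lower number, 0.011 mg/kg. Both gaps to compound 1 lie beyond the scatter.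

Compound 4 (`Cc1nc2cnccc2n1CC1CCN(C(=O)CC(C)(O)c2ccccc2)CC1`) has not yet been measured. It keeps the core of compound 1 and carries hydroxy in place of hydrogen on a saturated chain carbon bound to an aromatic carbon and two saturated chain carbons.

Going by the values given here, no measured pair shows a change of this kind, so the data offer no direct guide to its size. The only frame is the spread of the three measured values. A small rise in the number is expected, with no clear move beyond the scatter. The expected step is a 1.8-fold higher number from compound 1 to compound 4 (0.26 log units; within the scatter). For compound 4 the estimated value is 0.06 mg/kg, with an expected range of 0.015 mg/kg to 0.25 mg/kg.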

Compound 4, dose for 50% inhibition: 0.043 mg/kg
Estimate against measurement, compound 4: 1.4-fold (0.14 log units) above; measured number inside the range.
By their numbers in this assay, from the lowest: compound 3; then compounds 1 and 4 (each within the scatter of the next); then compound 2.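

Going by these compounds alone, at the saturated chain carbon bound to an aromatic carbon and two saturated chain carbons, hydroxy in place of hydrogen gives in this assay a 1.3-fold higher number from compound 1 to compound 4 (0.11 log units; within the scatter) and thus provides the first direct reading of a change at this position. The position therefore takes a hydroxy, with its hydrogen-bond donor and acceptor, without a step beyond the scatter on this whole-organism read-out. Nothing at hand explains this outcome.

The compounds shown leave open whether an amine or a methoxy on this same carbon would also stay within the scatter of compound 1. A single step also cannot show whether hydroxy would behave the same way on a different amide or sulfonyl side chain of the shared core.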